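Hydrazone aryl substituent and maltase-glucoamylase inhibition

The source may report more compounds than this note shows. Statements on the series, on what has been measured and on what is new or still open speak of the compounds shown alone.

Measured so far:
compound 1, `O=C(N/N=C/c1ccc(O)cc1)c1ccc(-c2nc3ccccc3s2)cc1`: 11300 nM
compound 2, `O=C(N/N=C/c1ccc(O)c(O)c1)c1ccc(-c2nc3ccccc3s2)cc1`: 15100 nM
compound 3, `O=C(N/N=C/c1ccc([N+](=O)[O-])cc1)c1ccc(-c2nc3ccccc3s2)cc1`: 26400 nM

Three hydrazones on the shared core of compound 1 have been tested in an assay on isolated protein for inhibition of Maltase-glucoamylase (Homo sapiens), with a stated time of 15 min; on this read-out lower numbers stand for stronger inhibition and higher numbers for weaker inhibition. Compound 3 gives the highest of the three numbers: the step of a 2.3-fold higher number from compound 1 to compound 3 (0.37 log units; beyond the scatter) lies beyond the scatter, whereas the step of a 1.7-fold higher number from compound 2 to compound 3 (0.24 log units; within the scatter) does not, and the step of a 1.3-fold higher number from compound 1 to compound 2 (0.13 log units; within the scatter) is also within the scatter.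

The next compound, compound 4 `O=C(N/N=C/c1ccc(Cl)cc1)c1ccc(-c2nc3ccccc3s2)cc1`, differs from compound 3 by a single change: chloro in place of nitro on an aromatic carbon. Within the data shown here, no measured pair shows a chloro group, so only the steps at this position bear on it. The step from compound 1 to compound 3 shows that the nitro group is on the weaker side of what has been seen, while the step from compound 1 to compound 2 shows that a second hydroxy group makes no difference beyond the scatter. Compound 4 is therefore expected to move back toward compound 1, by a step of about a 1.8-fold lower number from compound 3 to compound 4 (0.25 log units; within the scatter), giving an estimated 15000 nM with a range from 7000 nM to 40000 nM.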

Compound 4, half-maximal inhibitory concentration: 5310 nM
Compound 4: middle estimate off by 2.8-fold (0.45 log units), on the high side; measured number below the stated range.
By their numbers in this assay, from the lowest: compound 4; then compounds 1, 2 and 3 (each within the scatter of the next, the first and the last beyond it).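

In this assay, the substituent on the aromatic carbon para to a large group can now be seen to move the number below that of the hydroxy compound as well as above it: chloro in place of nitro gives the largest step seen so far (a 5.0-fold lower number from compound 3 to compound 4 (0.70 log units; beyond the scatter)), and chloro in place of hydroxy also lies beyond the scatter (a 2.1-fold lower number from compound 1 to compound 4 (0.33 log units; beyond the scatter)). The 4-chlorophenyl group likewise stands clear of the 3,4-dihydroxyphenyl group (a 2.8-fold lower number from compound 2 to compound 4 (0.45 log units; beyond the scatter)), which makes compound 4 the strongest inhibitor of the four. No measurement at hand accounts for the advantage of chloro over the other groups.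

The compounds shown leave open whether this gain is particular to chloro or would also appear with bromo, methyl or methoxy at this position, and whether an amine there would behave like hydroxy. They also leave open whether chloro on another carbon of this ring would give a similar step.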